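From cyano to ethoxycarbonyl on the ethenyl chain

The source may hold more compounds than are shown below. What is called first, only, known or untested is meant among the compounds shown, and "the series" means these compounds.

In a functional assay on SEM cells (Homo sapiens) for cytotoxicity, with a stated time of 72 h (on this read-out higher numbers stand for an effect only at larger amounts of compound and lower numbers for an effect already at smaller amounts), compound 1 `C=C[C@@](C)(/C=C/c1ccc(O)c(C=O)c1)CCC=C(C)C` gives 8510 nM and compound 2 `C=C[C@@](C)(/C=C/c1ccc(O)c(/C=C/C(=O)c2ccccc2)c1)CCC=C(C)C` gives 8000 nM on the same read-out. Compound 3 `C=C[C@@](C)(/C=C/c1ccc(O)c(/C=C/C#N)c1)CCC=C(C)C` gives only a limit of the assay > 36600 nM and no number. Compound 4 `C=C[C@@](C)(/C=C/c1ccc(O)c(/C=C/C(=O)OCC)c1)CCC=C(C)C` has ethoxycarbonyl in place of cyano on a double-bonded chain carbon bound to a double-bonded chain carbon and is otherwise unchanged. Within the data shown here, two measured steps bear on this: an at least 4.5-fold higher number from compound 2 to compound 3 (0.66 log units; beyond the scatter) with cyano in place of benzoyl at that place, and an at least 4.3-fold higher number from compound 1 to compound 3 (0.63 log units; beyond the scatter) with 2-cyanoethenyl in place of formyl. Removing cyano is therefore expected to lower the number, by a size left open by the limit. The expected change is an at least 2.4-fold lower number from compound 3 to compound 4 (0.38 log units; beyond the scatter) in this assay and is only a rough estimate. Compound 4 is estimated at 15000 nM (range 6000 nM to 36600 nM).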

Compound 4, half-maximal effective concentration: > 36600 nM
Compound 4: only a limit was reported (the forecaster's own chance of this, stated with the estimate: 25%); at least 2.4-fold (0.38 log units) between middle value and limit.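

The 2-(ethoxycarbonyl)ethenyl chain falls short of the two compounds with a readable number, as 2-cyanoethenyl does: this assay gives an at least 4.5-fold higher number from compound 2 to compound 4 (0.66 log units; beyond the scatter) with ethoxy in place of phenyl on the carbonyl carbon, and an at least 4.3-fold higher number from compound 1 to compound 4 (0.63 log units; beyond the scatter) with 2-(ethoxycarbonyl)ethenyl in place of formyl on the aromatic carbon. A carbonyl on this chain is thus not enough to match compound 2. The step from cyano to ethoxycarbonyl cannot be read, because compound 3 and compound 4 sit at one limit: the limit of > 36600 nM in this assay, at which 2 of the 4 values shown sit.

Open, going by these compounds, is whether an amine or a carboxylic acid in place of ethoxy brings the number back towards that of compound 2.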